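A few compounds are considered here, and "the series" means these few. Any claim that something is new, unique, unknown or untested is made for them only; others in the source may bear on it.

Measured in a functional assay on MDA-MB-435 cells (Homo sapiens) for cytotoxicity, read by sulforhodamine B assay, with a stated time of 48 h; a higher number here means a weaker inhibitor of growth, a lower number a stronger inhibitor of growth:
- compound 1 `COc1cc(C(=O)c2ccc3c(c2)oc(=O)n3S(C)(=O)=O)cc(OC)c1OC`: 289 nM
- compound 2 `COc1ccc(C(=O)c2cc(OC)c(OC)c(OC)c2)c(OC)c1O`: < 10 nM (a limit)

For compound 2, < 10 nM in this assay is a limit of the assay and not a number. Compound 3 `COc1ccc(C(=O)c2cc(OC)c(OC)c(OC)c2)c(OC)c1NC(C)=O` carries acetamido in place of the hydroxy of compound 2, on an aromatic carbon ortho to two methoxy groups: acetamido in place of hydroxy on an aromatic carbon.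

No measured step sizes this change, so the expectation rests on the structural change alone. The direction expected in this assay is towards a weaker inhibitor of growth, by a step beyond the scatter. Compound 1, at 289 nM, serves as a rough guide to the order of the number. The expected change is an at least 15-fold higher number from compound 2 to compound 3 (1.17 log units; beyond the scatter). Compound 3 is estimated at 150 nM, with an expected range of 20 nM to 1000 nM.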

Compound 3, concentration for 50% growth inhibition: 344000 nM
Estimate against measurement, compound 3: 2300-fold (3.36 log units) below, and the stated range ends below it.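

In this assay, acetamido in place of hydroxy on an aromatic carbon ortho to two methoxy groups gives an at least 34000-fold higher number from compound 2 to compound 3 (4.53 log units; beyond the scatter), so this position does not tolerate this exchange in this compound pair. Hydroxy and acetamido each count 1 hydrogen-bond donor and 1 hydrogen-bond acceptor, so those counts alone do not follow the loss, while the heavy atoms rise from 1 to 4. The value of compound 2, < 10 nM, is a limit of the assay and not a number, so the step marks a floor and its full size stays unread: the limit of < 10 nM in this assay, at which 1 of the 3 values shown sits.

Going by these compounds, whether the loss follows the nitrogen or the rest of the acetamido stays open. An amine at this position would separate the two, and a fluorine would show whether any group without the hydroxy keeps growth inhibition.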